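The source may report more compounds than this note shows. Statements on the series, on what has been measured and on what is new or still open speak of the compounds shown alone.

For the measured compounds named here, in a functional assay on MCF7 cells (Homo sapiens) for inhibition, read by sulforhodamine B assay (a lower number here means a stronger inhibitor of growth, a higher number a weaker inhibitor of growth), two compounds with a shared core have numbers so far. Compound 1 (`Fc1ccc(-c2ccc(-c3ccc(-c4nc5ccccc5[nH]4)cc3)cc2)cc1`) gives 36200 nM, and compound 2 (`CN(C)c1ccc(-c2ccc(-c3ccc(-c4nc5ccccc5[nH]4)cc3)cc2)cc1`) gives 41200 nM. Going by the values given here, compound 2 therefore stands level with the only other measured compound, and the two cannot be ranked against each other.

Compound 3 (`Clc1cccc(-c2ccc(-c3ccc(-c4nc5ccccc5[nH]4)cc3)cc2)c1`) has not yet been measured. It carries 3-chlorophenyl in place of 4-(dimethylamino)phenyl on an aromatic carbon.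

Among the compounds with values here, only one measured step bears on this change. Exchanging fluoro for dimethylamino on an aromatic carbon gave a 1.1-fold higher number from compound 1 to compound 2 (0.06 log units; within the scatter). Within the data shown here, that is thin evidence, since no chlorine-bearing compound has been tested and the step covers a single exchange. With that single step as the guide, no shift beyond the scatter is expected in this assay, and no direction can be favoured.

The expected change is a 1.1-fold lower number from compound 2 to compound 3 (0.05 log units; within the scatter), which is an estimate of no real movement. For compound 3 the estimated value is 37000 nM, with an expected range from 15000 nM to 80000 nM.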

Compound 3, concentration for 50% growth inhibition: 36300 nM
For compound 3 the middle estimate is 1.0-fold (0.01 log units) above the measured one; measured number inside the range.
By their numbers in this assay, from the lowest: compounds 1, 3 and 2 (each within the scatter of the next).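

In this assay, the exchange at this position gave a 1.1-fold lower number from compound 2 to compound 3 (0.05 log units; within the scatter), and the comparison with the fluorinated compound gave a 1.0-fold higher number from compound 1 to compound 3 (0.00 log units; within the scatter). For the compounds shown here, until now only one exchange had been seen here, between 4-fluorophenyl and 4-(dimethylamino)phenyl, in which the substituent changed while the numeral in the group's name stayed the same; with 3-chlorophenyl, both the substituent and that numeral change, and the step still stays within the scatter, so three different substituted phenyl groups on this aromatic carbon, para to a large group, now cannot be ranked against one another. No measurement is at hand that could explain why these exchanges leave the number in place.

The compounds shown leave open whether any group at this position can move the number beyond the scatter, for example a carboxylic acid or a longer chain in place of these substituted phenyl groups. All three compounds also share one core, so they say nothing about how a change elsewhere in the structure would act in this assay.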